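From compound 3 to compound 4: a group exchange

The compounds below may be only part of what the source reports. "The series", "measured", "known", "first", "only" and "open" are said of these compounds alone.

In a functional assay on DU-145 cells (Homo sapiens) for inhibition, read by trypan blue exclusion, with a stated time of 96 h (a lower number here means a stronger inhibitor of growth, a higher number a weaker inhibitor of growth), compound 3 `CSc1ccc(/C=C(/SCc2ccc(Cl)cc2)C(=O)c2ccc(C(=O)O)cc2)cc1` gives > 100000 nM, which is a limit of the assay and not a number. Its place in the series is therefore (the limit of > 100000 nM in this assay, at which 1 of the 3 values shown sits).

Compound 4 `O=C(O)c1ccc(C(=O)/C(=C\c2ccc(F)c([N+](=O)[O-])c2)SCc2ccc(Cl)cc2)cc1` is reached from it by one change: 4-fluoro-3-nitrophenyl in place of 4-(methylsulfanyl)phenyl on a double-bonded chain carbon bound to a double-bonded chain carbon. That is 4-fluoro-3-nitrophenyl in place of 4-(methylsulfanyl)phenyl on a double-bonded chain carbon bound to a double-bonded chain carbon. The group on sulfur stays as in compound 3.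

Going by the values given here, no measured step covers this exchange directly. The nearest evidence is the pair that already carries the entering group. Compound 1 `O=C(O)c1ccc(C(=O)/C(=C\c2ccc(F)c([N+](=O)[O-])c2)SCc2ccc(Cl)cc2Cl)cc1` gives 1000 nM in this assay, and compound 2 `O=C(O)c1ccc(C(=O)/C(=C\c2ccc(F)c([N+](=O)[O-])c2)SCc2ccc(F)cc2)cc1` gives 1000 nM. Among the compounds with values here, the one measured step between them, no change at the digits printed from compound 1 to compound 2 (within the scatter), replaces 2,4-dichlorophenyl with 4-fluorophenyl on a saturated chain carbon bound to a sulfur. Within the data shown here, the group on sulfur in compound 4 is not one of these two, but with no change at the digits printed from compound 1 to compound 2 (within the scatter) as the only guide, that difference is expected to matter little.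

As far as these compounds go, a large gain in growth inhibition is therefore expected, well beyond the scatter, though its exact size stays open while compound 3 has only a limit: an at least 100-fold lower number from compound 3 to compound 4 (2.00 log units; beyond the scatter) is the estimated step.

For compound 4 the estimate is 1000 nM, with an expected range of 300 nM to 4000 nM.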

Compound 4, concentration for 50% growth inhibition: 50000 nM
Compound 4: middle estimate off by 50-fold (1.70 log units), on the low side, outside the stated range (above it).
By their numbers in this assay, from the lowest: compounds 1 and 2 (each within the scatter of the next); then compound 4. At a limit, above all of these: compound 3.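

In this assay, the exchange of 4-(methylsulfanyl)phenyl for 4-fluoro-3-nitrophenyl on a double-bonded chain carbon can be read only as a floor, an at least 2.0-fold lower number from compound 3 to compound 4 (0.30 log units; that floor lies within the scatter), and with 4-chlorophenyl on the saturated chain carbon bound to sulfur, 4-fluoro-3-nitrophenyl does not bring the number to those of compounds 1 and 2. The group on sulfur is not silent, as the earlier step alone suggested, no change at the digits printed from compound 1 to compound 2 (within the scatter): there is a 50-fold higher number from compound 2 to compound 4 (1.70 log units; beyond the scatter) for chloro in place of fluoro on an aromatic carbon, and a 50-fold higher number from compound 1 to compound 4 (1.70 log units; beyond the scatter) for hydrogen in place of chloro on an aromatic carbon. Compound 4 thus stands apart from both neighbours, and no steady trend runs through these three groups on sulfur.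

As far as these compounds go, compound 3 is held only at a limit of the assay, not a number, and the full size of the exchange stays open: the limit of > 100000 nM in this assay, at which 1 of the 4 values shown sits. Also open is whether an unsubstituted phenyl or a 4-bromophenyl on that chain carbon falls with compounds 1 and 2 or with compound 4.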